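The source may hold more compounds than are shown below. What is called first, only, known or untested is meant among the compounds shown, and "the series" means these compounds.

Compound 2 `C=CCc1cc(C(C)=O)c(O)cc1OCCCCC#N` stands second highest of the three numbers in an assay on isolated protein for binding affinity to leukotriene B4 receptor 1 (Homo sapiens), tested at 1 uM (a lower number here means less inhibition, a higher number more inhibition at the concentration tested (going by the name of the read-out)), where compound 2 gives 57%. Compound 3 `C=CCc1cc(C(C)=O)c(O)cc1OCCCCCC(C)=O` gives 58%, the pair separated by a number 1 percentage points higher from compound 2 to compound 3 (within the scatter), while compound 1 `C=CCc1cc(C(C)=O)c(O)cc1OCC#N` gives 2%; the steps of a number 55 percentage points higher from compound 1 to compound 2 (beyond the scatter) and a number 56 percentage points higher from compound 1 to compound 3 (beyond the scatter) were large. Compound 4 `C=CCc1cc(C(C)=O)c(OC)cc1OCCCCC#N` differs from compound 2 by methyl in place of hydrogen on an oxygen on an aromatic ring. Within the data shown here, no measured step bears directly on this: all three alter the chain, none changes hydroxy to methoxy, so the series offers no guide to its size or direction. With that gap acknowledged, the account expects a lower number, estimating the change as a number 27 percentage points lower from compound 2 to compound 4 (beyond the scatter). Compound 4 is therefore expected to give 30%, with a range from 5% to 60%.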

Compound 4, a percentage reported as inhibition, at one concentration (the size of the read-out at that concentration, not a potency): 8%
For compound 4 the middle estimate is 22 percentage points above the measured one, within the range that was stated.
By their numbers in this assay, from the lowest: compounds 1 and 4 (each within the scatter of the next); then compounds 2 and 3 (each within the scatter of the next).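

Until now only the chain had changed, and this step shows that the oxygen on the aromatic ring also matters: in this assay the change from hydroxy to methoxy gives a number 49 percentage points lower from compound 2 to compound 4 (beyond the scatter) with the chain held constant. Adding a single heavy atom at this place thus removes most of the inhibition seen with compound 2. No evidence at hand says why. As far as these compounds go, it remains open whether an amine in place of the hydroxy, or an ethyl group on this oxygen, would retain inhibition, and whether methyl here has the same effect with the longer ketone chain of compound 3.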